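The source may report more compounds than this note shows. Statements on the series, on what has been measured and on what is new or still open speak of the compounds shown alone.

Measured so far:
compound 1 `O=C(/C=C/C(=O)N1C/C(=C\c2ccc([N+](=O)[O-])cc2)C(=O)/C(=C/c2ccc([N+](=O)[O-])cc2)C1)Nc1ccc(Cl)cc1` — 3600 nM
compound 2 `Cc1cccc(C)c1NC(=O)/C=C/C(=O)N1C/C(=C\c2ccc([N+](=O)[O-])cc2)C(=O)/C(=C/c2ccc([N+](=O)[O-])cc2)C1` — 690 nM

Going by the values given here, in a functional assay on L1210 cells (Mus musculus) for cytotoxicity (a higher number here means a weaker inhibitor, a lower number a stronger inhibitor), compound 2 holds the lower of the two numbers; the only measured step is a 5.2-fold lower number from compound 1 to compound 2 (0.72 log units; beyond the scatter). Compound 3 `O=C(/C=C/C(=O)N1C/C(=C\c2ccc([N+](=O)[O-])cc2)C(=O)/C(=C/c2ccc([N+](=O)[O-])cc2)C1)Nc1ccccc1` differs from compound 2 by phenyl in place of 2,6-dimethylphenyl on an amide-type nitrogen. Among the compounds with values here, that earlier step bears on the same position and shows that the group on that nitrogen moves the number, yet no measured step removes methyl groups, so the direction for compound 3 remains open. Compound 3 is expected to give a somewhat higher number, a step of a 2.2-fold higher number from compound 2 to compound 3 (0.34 log units; beyond the scatter). The estimated value of compound 3 is 1500 nM, with a range of 500 nM to 4500 nM.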

Compound 3, half-maximal inhibitory concentration: 1800 nM
Compound 3: middle estimate off by 1.2-fold (0.08 log units), on the low side; the range from low to high includes it.
By their numbers in this assay, from the lowest: compound 2; then compounds 3 and 1 (each within the scatter of the next).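

In this assay, phenyl in place of 2,6-dimethylphenyl on the amide-type nitrogen gives a 2.6-fold higher number from compound 2 to compound 3 (0.42 log units; beyond the scatter) and so shows that compound 2 stands apart from the unsubstituted phenyl as well as from the 4-chlorophenyl compound. Hydrogen in place of chloro on an aromatic carbon gives a 2.0-fold lower number from compound 1 to compound 3 (0.30 log units; within the scatter) and so separates compound 1 and compound 3 by no more than the usual scatter. No measurement is at hand to explain either step. The compounds shown leave open whether a single methyl group on the phenyl ring would match the two methyl groups of compound 2, and how an amine or a carboxylic acid on that ring would read.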